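Shortening a Sulfonyl Chain and Heat Stability

The source may hold more compounds than are shown below. What is called first, only, known or untested is meant among the compounds shown, and "the series" means these compounds.

Compound 1 `CC1(C)C(=O)N(CCCCO)C(C)(C)N1Cl`: in a physicochemical assay for metabolic stability, at 40 degrees C (a lower number here means that the compound disappears faster, a higher number that the compound lasts longer), compound 1 reaches the assay limit of > 2200 h.
Compound 2 `CC1(C)CN(CCS(=O)(=O)CCCS(=O)(=O)O)C(=O)N1Cl`: in this assay compound 2 reaches the assay limit of > 2680 h.

Compound 2 stands at a limit rather than a number in this assay, namely (the limit of > 2680 h in this assay, at which 1 of the 2 values shown sits). For the measured compounds named here, compound 1 also sits at a limit, (the limit of > 2200 h in this assay, at which 1 of the 2 values shown sits), so both results show only that each compound lasts very long. Compound 3 `CC1(C)CN(CCS(=O)(=O)O)C(=O)N1Cl` differs from compound 2 by hydroxy in place of 3-sulfopropyl on a sulfonyl sulfur. Going by the values given here, no measured pair shares this change, so no step size is known from the data. The step of a number no higher from compound 2 to compound 3 (the limit leaves the size open) is expected to be none beyond the usual scatter. Compound 3 is therefore expected to give 2680 h, within 1300 h to 5400 h, and quite possibly again only a limit.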

Compound 3, half-life: > 2200 h
Compound 3: only a limit was reported (the forecaster's own chance of this, stated with the estimate: 80%); the middle value is on the limit's open side.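

For the compounds shown here, compound 2 and compound 3 each give only a limit in this assay, and no step between them can be read. As far as these compounds go, how long each compound really lasts, and whether hydroxy in place of 3-sulfopropyl changes that, stays open.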